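This account rests on a few compounds, and the source may have more. Where it says the series, first, only, none or still open, it means among the compounds named here.

Measured in a functional assay for inhibition, with Sus scrofa as the target; on this read-out lower numbers stand for stronger inhibition and higher numbers for weaker inhibition:
Compound 1 `CC1(C)Oc2ccc(C#N)cc2[C@@H](n2ccccc2=O)[C@@H]1O`: 300 nM
Compound 2 `CC1(C)Oc2ccc(C#N)cc2[C@@H](Oc2ccc(=O)[nH]n2)[C@@]1(O)Cc1ccccc1`: > 100000 nM (a limit of the assay, not a number)
Compound 3 `Cn1nc(O[C@@H]2c3cc(C#N)ccc3OC(C)(C)[C@@]2(C)O)ccc1=O`: 30 nM

Compound 2 is the only one of these compounds without a number. Compound 2 sits on (the limit of > 100000 nM in this assay, at which 1 of the 3 values shown sits), so its true value is not known.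

Compound 4 `CC1(C)Oc2ccc(C#N)cc2[C@@H](Oc2ccc(=O)[nH]n2)[C@@]1(O)CO` departs from compound 2 in a single place: hydroxy in place of phenyl on a saturated chain carbon bound to a saturated ring carbon. Hydroxy takes the place of phenyl on a saturated chain carbon bound to a saturated ring carbon, which turns benzyl into hydroxymethyl.

Within the data shown here, no measured pair of compounds shows this change on its own, so the expectation rests on the values alone. Compound 1 gives 300 nM and compound 3 gives 30 nM, which shows that inhibition can be measured as a number among these compounds. In this assay a large step towards stronger inhibition is therefore expected, although its size stays uncertain with a limit as the starting point. The expected change is an at least 33-fold lower number from compound 2 to compound 4 (1.52 log units; beyond the scatter). For compound 4 the estimated value is 3000 nM, with an expected range of 300 nM to 30000 nM.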

Compound 4, half-maximal inhibitory concentration: 700 nM
Estimate against measurement, compound 4: 4.3-fold (0.63 log units) above; the range from low to high includes it.
By their numbers in this assay, from the lowest: compound 3; then compound 1; then compound 4. At a limit, above all of these: compound 2.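

In this assay, the change from benzyl to hydroxymethyl, which puts hydroxy in place of phenyl on a saturated chain carbon bound to a saturated ring carbon, gives an at least 140-fold lower number from compound 2 to compound 4 (2.15 log units; beyond the scatter). Among these compounds, this is the first direct reading of a single change at this place, and it shows that the group carried there can decide whether the read-out gives a number at all, since compound 4 gives 700 nM with the rest of the structure unchanged. The true size of the step remains unknown, as the value for compound 2 is a limit of the assay and not a number: the limit of > 100000 nM in this assay, at which 1 of the 4 values shown sits.

This one step cannot separate the loss of phenyl from the entry of hydroxy, so it leaves open whether the gain comes from removing the aromatic ring, from adding the hydroxy, or from both. A methoxymethyl or aminomethyl group, or a longer chain ending in hydroxy, at this place would show how closely the result depends on hydroxymethyl itself.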